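The source may report more compounds than this note shows. Statements on the series, on what has been measured and on what is new or still open speak of the compounds shown alone.

Compound 1 `CCCC(=O)N1N=C(c2cc(OC)ccc2N)SC1(C)C` is the starting point of this comparison. For the measured compounds named here, in an assay on isolated protein for inhibition of Nitric oxide synthase, inducible (Homo sapiens), read by scintillation counting, with a stated time of 30 min, tested at 50 uM (on this read-out higher numbers stand for more inhibition at the one concentration tested (going by the name of the read-out) and lower numbers for less inhibition), compound 1 gives 91.1%, the higher of the two numbers measured so far. Its nearest neighbour, compound 2 `COc1ccc(N)c(C2=NN(C(=O)C3CC3)C(C)(C)S2)c1`, gives 90.1% in this assay; the step of a number 1 percentage points lower from compound 1 to compound 2 (within the scatter) comes from cyclopropyl in place of propyl on a carbonyl carbon and lies within the scatter. Compound 3 `COc1ccc(N)c(C2=NN(C(=O)C3CCCC3)C(C)(C)S2)c1` has not yet been measured; it differs from compound 1 in one place: cyclopentyl in place of propyl on a carbonyl carbon. Going by the values given here, the only measured step that bears on this change is the one from compound 1 to compound 2, where a ring replaced the propyl at the same carbonyl carbon without a shift beyond the scatter. On that basis no step beyond the scatter is expected for compound 3 in this assay, and the step of a number 3.1 percentage points lower from compound 1 to compound 3 (within the scatter) is estimated as small. Compound 3 is therefore expected to give about 88% in this assay, with a range from 74% to 96%.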

Compound 3, a percentage reported as inhibition, at one concentration (the size of the read-out at that concentration, not a potency): 65%
Estimate against measurement, compound 3: 23 percentage points above; measured number below the stated range.
By their numbers in this assay, from the lowest: compound 3; then compounds 2 and 1 (each within the scatter of the next).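

Moving to cyclopentyl at this carbonyl carbon in this assay gives a step that compound 2 had not shown: a number 26.1 percentage points lower from compound 1 to compound 3 (beyond the scatter), and likewise a number 25.1 percentage points lower from compound 2 to compound 3 (beyond the scatter). The position therefore does respond to the group it carries, and the presence of a ring does not settle the outcome, since cyclopropyl stays within the scatter of propyl while cyclopentyl does not. No measurement at hand accounts for this drop.

The compounds shown leave open where between cyclopropyl and cyclopentyl the loss sets in, a question that cyclobutyl at the same carbon would address. They also leave open whether it belongs to the ring itself or to the number of carbons, which a longer chain such as pentyl, or a ring carrying an amine, could help to separate.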